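Fluoro for cyano on the aryl ring of compound 2

The compounds below may be only part of what the source reports. "The series", "measured", "known", "first", "only" and "open" are said of these compounds alone.

Compound 1 `COCCNC(=O)c1cc2cccc(OC)c2oc1=O`: 18%
Compound 2 `COc1cccc2cc(C(=O)Nc3c(C#N)ncn3-c3ccc(C#N)cc3)c(=N)oc12`: 10%
Compound 3 `CCC(CO)NC(=O)c1cc2cccc(OC)c2oc1=N`: 39%

Three compounds share a methoxy-bearing bicyclic core and were tested in an assay on HEK293 cells for displacement of a labelled ligand from adenosine receptor A2b (Homo sapiens), read by scintillation counting, with a stated time of 30 min, tested at 10 uM; on this read-out lower numbers stand for less inhibition and higher numbers for more inhibition at the one concentration tested (going by the name of the read-out). Compound 1 gives 18%, compound 3 gives 39%, and compound 2 gives 10%. Compound 2 has the lowest of the three numbers; its gap to compound 1 lies within the scatter of the measurement, while its gap to compound 3 lies beyond it. Only compound 3 is thus clearly separated from compound 2 on this read-out.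

Compound 4 `COc1cccc2cc(C(=O)Nc3c(C#N)ncn3-c3ccc(F)cc3)c(=N)oc12` differs from compound 2 in one place: fluoro in place of cyano on an aromatic carbon. Going by the values given here, no measured pair in this set shows what such an exchange does in this assay, so nothing in the data points to a step in either direction. The step from compound 2 to compound 4 is expected to be a number 2 percentage points higher from compound 2 to compound 4 (within the scatter), that is, none beyond the scatter. Compound 4 is therefore estimated at 12%, with a range from 0% to 30%.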

Compound 4, a percentage reported as inhibition, at one concentration (the size of the read-out at that concentration, not a potency): 30%
For compound 4 the middle estimate is 18 percentage points below the measured one, within the range that was stated.
By their numbers in this assay, from the lowest: compounds 2 and 1 (each within the scatter of the next); then compounds 4 and 3 (each within the scatter of the next).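

In this assay, going by these compounds alone, the change from 4-cyanophenyl to 4-fluorophenyl gives the only step in this set, a number 20 percentage points higher from compound 2 to compound 4 (beyond the scatter). The earlier compounds shown here included no pair differing at one place, so they could not show that the group on this aromatic carbon, para to a large group, matters on this read-out, or that fluoro in place of cyano goes with more inhibition at the one concentration tested. Nothing at hand explains this step.

A single pair cannot tell whether the step follows from the arrival of fluoro or the departure of cyano, or whether it would recur on another core. The compounds shown also leave open what chloro, an amine or a carboxylic acid would give at this same place.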